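A Longer Amine Chain on Compound 1

The source may hold more compounds than are shown below. What is called first, only, known or untested is meant among the compounds shown, and "the series" means these compounds.

Measured so far in an ADME assay on HaCaT cells (Homo sapiens) for cytotoxicity, read by MTT assay, with a stated time of 72 h; on this read-out higher numbers stand for weaker inhibition and lower numbers for stronger inhibition:
- compound 1 `CCCCNC1=CC(=O)C=C(C(C)(C)C)C1=O`: 11000 nM
- compound 2 `CCCCNC1=CC(=O)C(C[C@]2(C)[C@@H](C)CC[C@]3(C)C(C)=CCC[C@@H]23)=CC1=O`: > 100000 nM

Among the measured compounds shown here, only one real number is available here: compound 1 gives 11000 nM. For compound 2, the entry > 100000 nM is a limit of the assay and not a number. That leaves compound 1 as the sole measured reference point in this assay.

The next compound to be tested is compound 3 `CCCCCCCCNC1=CC(=O)C=C(C(C)(C)C)C1=O`. It keeps the core of compound 1 and changes only the amine chain: butyl in place of hydrogen on a saturated chain carbon, four bonds along the chain from an amine nitrogen. In words, this places butyl in place of hydrogen on a saturated chain carbon, four bonds along the chain from an amine nitrogen.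

For the measured compounds named here, no two measured compounds differ in a single place, so the size of such a change has not yet been seen. The estimate therefore starts from compound 1 at 11000 nM and allows for wide uncertainty. A small shift toward stronger inhibition is expected, a 1.4-fold lower number from compound 1 to compound 3 (0.14 log units; within the scatter), and it may stay within the usual scatter. For compound 3 the expected value is 8000 nM, with an estimated range from 2500 nM to 25000 nM.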

Compound 3, half-maximal inhibitory concentration: 30000 nM
The estimate for compound 3 lay 3.8-fold (0.57 log units) below the measured number; measured number above the stated range.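

Among the compounds shown here, putting butyl in place of hydrogen on a saturated chain carbon, four bonds along the chain from the amine nitrogen, gives the first single-place comparison in this assay, with a 2.7-fold higher number from compound 1 to compound 3 (0.44 log units; beyond the scatter). Since a higher number on this read-out stands for weaker inhibition, this longer amine chain moves the result toward weaker cytotoxicity in these skin-derived cells, and the step lies beyond the usual scatter, although it is modest in size. The values shown offer no measured property that accounts for this step, so its cause remains unknown.

With just this one change on the shared core, a single step cannot show whether the number rises steadily with chain length, levels off or changes direction along the way. Methyl or propyl in place of hydrogen at this same chain carbon would test how the number follows chain length, while an amine or a carboxylic acid there would test whether any added group gives a similar shift or whether a plain carbon chain is needed.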